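This account rests on a few compounds, and the source may have more. Where it says the series, first, only, none or still open, it means among the compounds named here.

Measured in a functional assay on SMMC-7721 cells (Homo sapiens) for antiproliferative activity, read by MTT assay, with a stated time of 48 h; a lower number here means a stronger inhibitor, a higher number a weaker inhibitor:

- Compound 1 `Cn1cc(C2=C(c3nn(CCCn4cncn4)c4ncccc34)C(=O)NC2=O)c2ccccc21` gives > 100000 nM as a limit
- Compound 2 `Cn1cc(C2=C(c3nn(CCCn4cncn4)c4ncccc34)C(=O)N(c3ccccc3)C2=O)c2ccccc21` gives > 100000 nM as a limit
- Compound 3 `Cn1cc(C2=C(c3nn(CCn4ccnc4)c4ncccc34)C(=O)N(c3ccccc3)C2=O)c2ccccc21` gives > 100000 nM as a limit

Compound 1 therefore has a limit and no number. The whole series rests on (the limit of > 100000 nM in this assay, at which 3 of the 3 values shown sit), so it offers no numerical ranking. Compound 4 `Cn1cc(C2=C(c3nn(CCCn4cccc4)c4ncccc34)C(=O)NC2=O)c2ccccc21` keeps the core of compound 1 and carries 1H-pyrrol-1-yl in place of 1H-1,2,4-triazol-1-yl on a saturated chain carbon, three bonds along the chain from an aromatic nitrogen. Going by the values given here, the counted difference reads 1H-pyrrol-1-yl in place of 1H-1,2,4-triazol-1-yl on a saturated chain carbon, three bonds along the chain from an aromatic nitrogen and is the only change. Among the compounds with values here, two measured steps bear on it only loosely. The nearer is a step that the two limits leave unreadable from compound 2 to compound 3, which also alters the side chain, while a step that the two limits leave unreadable from compound 1 to compound 2 is a change on the amide-type nitrogen in a ring. Neither gives a size, so only a small step is expected in this assay, with any readable movement expected towards a stronger inhibitor. The expected change is an at least 1.2-fold lower number from compound 1 to compound 4 (0.09 log units; that floor lies within the scatter) in this estimate. Compound 4 is estimated at 80000 nM with an expected range from 20000 nM to 150000 nM and may well report only a limit.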

Compound 4, half-maximal inhibitory concentration: > 100000 nM
Compound 4: no number, only a limit; the forecaster's own chance of this, stated with the estimate: 55%; middle value at least 1.2-fold (0.09 log units) from the limit.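

In this assay compound 4 gives > 100000 nM, which is a limit and not a number. Going by these compounds alone, compound 1 also has only a limit, so no step between compound 1 and compound 4 can be read. The compounds shown leave open whether any of these changes moves the activity at all: the limit of > 100000 nM in this assay, at which 4 of the 4 values shown sit.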